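A few compounds are considered here, and "the series" means these few. Any claim that something is new, unique, unknown or untested is made for them only; others in the source may bear on it.

Among the measured compounds shown here, in a functional assay on HepG2 cells (Homo sapiens) for antiproliferative activity, read by MTT assay, with a stated time of 48 h (a lower number here means a stronger inhibitor, a higher number a weaker inhibitor), compound 1 (`Cc1ccc(Oc2nc3ccccc3cc2/C=N/NC(=O)Cn2c([N+](=O)[O-])cnc2C)cc1`) gives 27100 nM and compound 2 (`COc1ccc(Oc2nc3ccccc3cc2/C=N/NC(=O)Cn2c([N+](=O)[O-])cnc2C)cc1`) gives 4130 nM as the lower of the two numbers so far. Compound 3 (`Cc1ncc([N+](=O)[O-])n1CC(=O)N/N=C/c1cc2ccccc2nc1Oc1ccc(Cl)cc1`) has chloro in place of methoxy on an aromatic carbon para to a large group. For the measured compounds named here, the one measured change at this place is a 6.6-fold lower number from compound 1 to compound 2 (0.82 log units; beyond the scatter) with methoxy in place of methyl. Chloro is untested here, so a smaller step toward a higher number is expected, with the size uncertain. The expected change is a 2.2-fold higher number from compound 2 to compound 3 (0.34 log units; beyond the scatter) in this series. Compound 3 is estimated at 9000 nM within a range of 2500 nM to 30000 nM for now.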

Compound 3, half-maximal inhibitory concentration: 220 nM
Beside the measured number, compound 3's estimate is 41-fold (1.61 log units) above it; measured number outside the range, below it.
By their numbers in this assay, from the lowest: compound 3; then compound 2; then compound 1.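

In this assay the 4-chlorophenoxy group brings the largest drop so far at this place, with a 19-fold lower number from compound 2 to compound 3 (1.27 log units; beyond the scatter) and a 120-fold lower number from compound 1 to compound 3 (2.09 log units; beyond the scatter), both large beside the modest 6.6-fold lower number from compound 1 to compound 2 (0.82 log units; beyond the scatter). Methoxy therefore sits in the middle of the three groups at this place, with chloro and methyl at the two ends. Nothing measured on these compounds accounts for the size of the chloro step.

On these data alone, whether fluoro, bromo, trifluoromethyl or an amine at this place would match chloro stays open. So does whether the chloro gain carries over to other positions on the same aromatic ring.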